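Trimethoxyphenyl in place of methoxyphenyl on the amide nitrogen

A few compounds are considered here, and "the series" means these few. Any claim that something is new, unique, unknown or untested is made for them only; others in the source may bear on it.

Measured so far, all in a functional assay on PC-3 cells (Homo sapiens) for cytotoxicity, read by MTT assay, with a stated time of 48 h, in the presence of a further agent that is not named here; a lower number here means a stronger inhibitor, a higher number a weaker inhibitor:
compound 1 `COc1ccc(NC(=O)c2csc(-c3cn(Cc4ccc(Cl)cc4)c4ccccc34)n2)cc1` gives > 100000 nM, a limit of the assay and not a number.
compound 2 `Cc1ccc(NC(=O)c2csc(-c3c[nH]c4ccccc34)n2)cc1` gives > 100000 nM, also a limit.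
compound 3 `COc1cc(NC(=O)c2csc(-c3c[nH]c4ccc(F)cc34)n2)cc(OC)c1OC` gives > 100000 nM, also a limit.

Compound 1 therefore stands only at a limit in this assay; no number is known for it, and the whole measured set sits at the same limit (the limit of > 100000 nM in this assay, at which 3 of the 3 values shown sit). Compound 4 `COc1cc(NC(=O)c2csc(-c3cn(Cc4ccc(Cl)cc4)c4ccccc34)n2)cc(OC)c1OC` differs from compound 1 in one place: 3,4,5-trimethoxyphenyl in place of 4-methoxyphenyl on an amide-type nitrogen. For the measured compounds named here, no step between two measured compounds is available, so no measured step size can be quoted for this change. The nearest pointer is compound 3, which already carries 3,4,5-trimethoxyphenyl on the amide-type nitrogen, on a related core, and sits at the limit > 100000 nM. On that basis the expected step is a number no higher from compound 1 to compound 4 (the limit leaves the size open), none beyond the scatter. Compound 4 is estimated at 100000 nM, in the range 30000 nM to 300000 nM, with a limit rather than a number the most likely outcome.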

Compound 4, half-maximal inhibitory concentration: > 100000 nM
Compound 4: a limit, no number; the forecaster's own chance of this, stated with the estimate: 85%; the middle value lies on the limit itself.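

No step can be read between compound 1 and compound 4, since each value is a limit and not a number: the limit of > 100000 nM in this assay, at which 4 of the 4 values shown sit.

The compounds shown leave open whether 4-methoxyphenyl or 3,4,5-trimethoxyphenyl on the amide-type nitrogen differ at all in cytotoxicity.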